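The source may report more compounds than this note shows. Statements on the series, on what has been measured and on what is new or still open speak of the compounds shown alone.

Measured in a functional assay on L02 cells (Homo sapiens) for inhibition, read by Griess assay, with stated times of 1 h and 24 h; on this read-out higher numbers stand for weaker inhibition and lower numbers for stronger inhibition:

- Compound 1 `CN(C)c1nc(/C=C/c2ccccc2)nc2ccsc12`: > 1000000 nM, a limit
- Compound 2 `CCCCNc1nc(/C=C/c2ccccc2)nc2ccsc12`: > 1000000 nM, a limit
- Compound 3 `CC(C)CNc1nc(/C=C/c2ccccc2)nc2ccsc12`: > 1000000 nM, a limit

Compound 3 stands with the other two at one shared ceiling, (the limit of > 1000000 nM in this assay, at which 3 of the 3 values shown sit), so no number separates them. Compound 4 `CN1CCN(c2nc(/C=C/c3ccccc3)nc3ccsc23)CC1` carries 4-methylpiperazin-1-yl in place of isobutylamino on an aromatic carbon. The nearest measured changes also exchange one amino group for another: a step that the two limits leave unreadable from compound 1 to compound 3, a step that the two limits leave unreadable from compound 1 to compound 2 and a step that the two limits leave unreadable from compound 2 to compound 3. None has a readable size, so none gives a direction, and another reading at the limit seems most likely. The expected change is a number no higher from compound 3 to compound 4 (the limit leaves the size open), with nothing beyond the scatter anticipated. For compound 4 the estimated value is 1000000 nM, with an expected range of 300000 nM to 3000000 nM.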

Compound 4, half-maximal inhibitory concentration: 198000 nM
The estimate for compound 4 lay 5.1-fold (0.70 log units) above the measured number; measured number outside the range, below it.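

Among these compounds, at this position, on the aromatic carbon next to the ring nitrogen, 4-methylpiperazin-1-yl gives the first number that can be read in this assay, with an at least 5.0-fold lower number from compound 3 to compound 4 (0.70 log units; beyond the scatter), an at least 5.0-fold lower number from compound 2 to compound 4 (0.70 log units; beyond the scatter) and an at least 5.0-fold lower number from compound 1 to compound 4 (0.70 log units; beyond the scatter). So a change at this position can move the read-out, which the open-chain amino groups alone could not show. The full size of each step stays unknown because the other three compounds sit at a ceiling: the limit of > 1000000 nM in this assay, at which 3 of the 4 values shown sit.

The compounds shown leave open whether the ring or its second nitrogen goes with this change. Piperidin-1-yl, morpholin-4-yl or piperazin-1-yl without the methyl would help separate them.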